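The compounds below may be only part of what the source reports. "The series", "measured", "known", "first", "only" and "open" are said of these compounds alone.

Measured compounds in the series:
- compound 1 `c1cncc(-c2nc3ccccc3n2C2CC2)c1`: in an assay on V79 cells for inhibition of cytochrome P450 11B2, mitochondrial (Homo sapiens), read by HTRF, with a stated time of 1 h (a higher number here means a weaker inhibitor, a lower number a stronger inhibitor), compound 1 gives 49 nM
- compound 2 `COc1ccc2nc(-c3cccnc3)n(C3CC3)c2c1`: in this assay compound 2 gives 24 nM
- compound 3 `Clc1ccc2nc(-c3cccnc3)n(C3CC3)c2c1`: in this assay compound 3 gives 2.2 nM

Compound 3 has the lowest number of the three in this assay; the nearest is compound 2, with a step of an 11-fold lower number from compound 2 to compound 3 (1.04 log units; beyond the scatter), the furthest compound 1, with a step of a 22-fold lower number from compound 1 to compound 3 (1.35 log units; beyond the scatter). Methoxy in place of hydrogen gives only a 2.0-fold lower number from compound 1 to compound 2 (0.31 log units; beyond the scatter). The substituent on the shared core thus sets the spread of the series.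

Compound 4 `N#Cc1ccc2nc(-c3cccnc3)n(C3CC3)c2c1` differs from compound 3 by cyano in place of chloro on an aromatic carbon. Going by the values given here, no measured step exchanges chloro for cyano, so the two large steps that install chloro, a 22-fold lower number from compound 1 to compound 3 (1.35 log units; beyond the scatter) and an 11-fold lower number from compound 2 to compound 3 (1.04 log units; beyond the scatter), bear only indirectly: they show that a small group at this position can carry a large gain over hydrogen and over methoxy, and cyano is expected to keep most of it. The expected step of a 1.8-fold higher number from compound 3 to compound 4 (0.26 log units; within the scatter) lies near the scatter. Compound 4 is therefore estimated at 4 nM, with a range of 1.5 nM to 12 nM.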

Compound 4, half-maximal inhibitory concentration: 1.2 nM
Compound 4: middle estimate off by 3.3-fold (0.52 log units), on the high side, and the stated range ends above it.
By their numbers in this assay, from the lowest: compounds 4 and 3 (each within the scatter of the next); then compound 2; then compound 1.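

Notes on the position: in this assay, chloro and cyano read alike (a 1.8-fold lower number from compound 3 to compound 4 (0.26 log units; within the scatter)), so the gain at this aromatic carbon is not tied to chloro and also holds with a group of two heavy atoms that carries a triple bond and a hydrogen-bond acceptor. Cyano keeps a large separation from both hydrogen (a 41-fold lower number from compound 1 to compound 4 (1.61 log units; beyond the scatter)) and methoxy (a 20-fold lower number from compound 2 to compound 4 (1.30 log units; beyond the scatter)), leaving methoxy as the substituent that goes against the large gain seen with the other two groups. Nothing at hand gives a reason why chloro and cyano read alike here.

From the compounds shown here alone, whether the gain extends to bromo, an amine, a carboxylic acid or a longer chain at this position stays open. Also open, going by these compounds, are how cyano would read on another carbon of the same ring and how compound 3 and compound 4 compare against any other enzyme.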